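Aryl in place of heptyl on the core of compound 1

The compounds below may be only part of what the source reports. "The series", "measured", "known", "first", "only" and "open" are said of these compounds alone.

Working notes on the series. Compound 1 `CCCCCCCc1cn(C(c2ccccc2)c2cc3cc(Br)ccc3nc2OC)nn1` is the reference point; in an ADME assay on PANC-1 cells (Homo sapiens) for cytotoxicity, read by sulforhodamine B assay, with a stated time of 48 h, tested at 10 uM (on this read-out higher numbers stand for more inhibition at the one concentration tested (going by the name of the read-out) and lower numbers for less inhibition), compound 1 gives 16.6%, the highest of the three measured numbers. Compound 2 `CCCCCCc1cn(C(c2ccccc2)c2cc3cc(Br)ccc3nc2OC)nn1` gives 6.08% in this assay, and compound 3 `COc1nc2ccc(Br)cc2cc1C(c1ccccc1)n1cc(-c2ccc(OC(F)(F)F)cc2)nn1` gives 11.7%. Of the measured steps, a number 10.5 percentage points lower from compound 1 to compound 2 (beyond the scatter), whereas a number 4.9 percentage points lower from compound 1 to compound 3 (within the scatter), and a number 5.6 percentage points higher from compound 2 to compound 3 (within the scatter).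

Compound 4 `COc1nc2ccc(Br)cc2cc1C(c1ccccc1)n1cc(-c2cccc(F)c2)nn1` differs from compound 1 in one place: 3-fluorophenyl in place of heptyl on an aromatic carbon. The step that bears on it most directly is the one in which another aryl group replaced heptyl, a number 4.9 percentage points lower from compound 1 to compound 3 (within the scatter); the related step of a number 5.6 percentage points higher from compound 2 to compound 3 (within the scatter) points the same way. Neither of these exchanges of an alkyl chain for an aryl group produced a step beyond the scatter. Compound 4 is therefore expected to show a step of a number 4.6 percentage points lower from compound 1 to compound 4 (within the scatter), not beyond the scatter. In this assay compound 4 is estimated at 12%, with a range from 2% to 24%.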

Compound 4, a percentage reported as inhibition, at one concentration (the size of the read-out at that concentration, not a potency): 15.5%
Beside the measured number, compound 4's estimate is 3.5 percentage points below it, and the stated range covers the measured number.
By their numbers in this assay, from the lowest: compounds 2, 3, 4 and 1 (each within the scatter of the next, the first and the last beyond it).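

In this assay, a second aryl group on this aromatic carbon of the five-membered ring replaces heptyl with no step beyond the scatter, giving a number 1.1 percentage points lower from compound 1 to compound 4 (within the scatter). Exchanging one aryl group for another at the same place, 3-fluorophenyl in place of 4-(trifluoromethoxy)phenyl, gives a number 3.8 percentage points higher from compound 3 to compound 4 (within the scatter), so the two aryl groups are not separated here. With 3-fluorophenyl in place of hexyl giving a number 9.4 percentage points higher from compound 2 to compound 4 (within the scatter), both aryl groups now lie within the scatter of both chains, although the two chains are not within it of each other.

No measurement is at hand that accounts for these numbers. As far as these compounds go, whether an amine or a carboxylic acid on the aryl ring, or a chain longer than heptyl at this aromatic carbon, would give a step beyond the scatter stays open.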